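Lengthening the Cyano Chain at the Limit of the Assay

The compounds below may be only part of what the source reports. "The series", "measured", "known", "first", "only" and "open" are said of these compounds alone.

In a toxicity assay on HT-29 cells (Homo sapiens) for cytotoxicity (on this read-out higher numbers stand for lower toxicity in this test and lower numbers for higher toxicity in this test), compound 1 `CN1C(=S)[C@@H](NC(=O)c2nc(Cc3ccccc3)n(C)n2)COc2ccccc21` gives > 100000 nM as a limit, not a number. Compound 2 `CC(C)CCn1nc(C(=O)N[C@H]2COc3ccccc3N(C)C2=S)nc1Cc1ccccc1` gives > 100000 nM as a limit too. Compound 3 `CN1C(=S)[C@@H](NC(=O)c2nc(Cc3ccccc3)n(CCCCC#N)n2)COc2ccccc21` gives > 100000 nM and also stands at a limit. Together they show the limit of > 100000 nM in this assay, at which 3 of the 3 values shown sit, and no exact value. Compound 4 `CN1C(=S)[C@@H](NC(=O)c2nc(Cc3ccccc3)n(CCCCCC#N)n2)COc2ccccc21` differs from compound 3 by cyanomethyl in place of cyano on a saturated chain carbon, four bonds along the chain from an aromatic nitrogen and in words this is cyanomethyl in place of cyano on a saturated chain carbon, four bonds along the chain from an aromatic nitrogen. The same difference reads 3-cyanopropyl to 4-cyanobutyl. The measured steps, a step that the two limits leave unreadable from compound 1 to compound 3 and a step that the two limits leave unreadable from compound 2 to compound 3 and a step that the two limits leave unreadable from compound 1 to compound 2 as well, offer no size to build on. No shift beyond the scatter is therefore expected in this assay and no direction can be foreseen. The expected step is a number no higher from compound 3 to compound 4 (the limit leaves the size open) on this estimate. For compound 4 the estimated value is 100000 nM with an expected range from 50000 nM to 200000 nM in this test.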

Compound 4, half-maximal cytotoxic concentration: > 100000 nM
Compound 4: a limit, no number (the forecaster's own chance of this, stated with the estimate: 90%); the middle value lies on the limit itself.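

In this assay compound 4 gives > 100000 nM, a limit and not a number. No step from compound 1, compound 2 or compound 3 to compound 4 can be read: the limit of > 100000 nM in this assay, at which 4 of the 4 values shown sit.

On these data alone, whether these four compounds differ at all in toxicity stays open.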